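Removing a tert-butoxycarbonyl cap: expected plasma half-life

The source may report more compounds than this note shows. Statements on the series, on what has been measured and on what is new or still open speak of the compounds shown alone.

Of the compounds shown here, three sharing the same unsaturated ester chain have been measured in an ADME assay on a cell-free system (plasma, Homo sapiens) for metabolic stability; a higher number here means that the compound lasts longer, a lower number that the compound disappears faster. Compound 1, `CCOC(=O)/C=C/[C@H](CC(C)C)NC(=O)[C@H](CC(C)C)NC(=O)[C@H](CC(C)C)NC(=O)c1cccc(O)c1C`, gives > 6 h, which is a limit of the measurement rather than a number. Compound 2, `CCOC(=O)/C=C/[C@H](CC(C)C)NC(=O)[C@H](CO)NC(=O)[C@@H](NC(=O)OCc1ccccc1)C(C)C`, gives 3.97 h. Compound 3, `CCOC(=O)/C=C/[C@H](CC(C)C)NC(=O)[C@H](CO)NC(=O)[C@@H](NC(=O)C1=CCCN(C(=O)OC(C)(C)C)C1)C(C)C`, gives 2.57 h; this number and that of compound 2 lie within the usual scatter of each other, so the two cannot be told apart on the present data. Compound 4, `CCOC(=O)/C=C/[C@H](CC(C)C)NC(=O)[C@H](CO)NC(=O)[C@@H](NC(=O)C1=CCCNC1)C(C)C`, has not been measured yet. It differs from compound 3 in one place: hydrogen in place of tert-butoxycarbonyl on an amine nitrogen in a ring. Within the data shown here, no measured pair of compounds shows what this change does in this assay, so the expectation rests on compound 3 alone. The change is expected to move the half-life by no more than the scatter, with no clear direction, a 1.0-fold lower number from compound 3 to compound 4 (0.01 log units; within the scatter). Compound 4 is therefore estimated at 2.5 h, with a range from 1.2 h to 5 h.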

Compound 4, half-life: > 6 h
Compound 4 gave a limit, no number (the forecaster's own chance of this, stated with the estimate: 10%); middle value at least 2.4-fold (0.38 log units) away from the limit.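

Among these compounds, putting hydrogen in place of tert-butoxycarbonyl on the amine nitrogen in the ring gives an at least 2.3-fold higher number from compound 3 to compound 4 (0.36 log units; beyond the scatter) in this assay, the first measured reading of this change at this position, and it lengthens the half-life. With a group of 6 heavy atoms in place of a group of 8 heavy atoms on a carbonyl carbon, the result is an at least 1.5-fold higher number from compound 2 to compound 4 (0.17 log units; that floor lies within the scatter), so this floor does not separate compound 4 from compound 2. The full size of both steps stays unknown because the result for compound 4 is a limit: the limit of > 6 h in this assay, at which 2 of the 4 values shown sit.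

The compounds shown leave open whether an acetyl or a methyl group on this ring nitrogen would give the same result as hydrogen. They also leave open whether this change would have the same outcome with the leucine-type chains of compound 1.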